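The compounds below may be only part of what the source reports. "The series", "measured", "known", "first", "only" and "open" are said of these compounds alone.

Compound 1 `COc1cc(C(=O)c2sc3ccccc3c2-c2ccc(F)cc2)cc(OC)c1OC` is the reference point of this set. In a functional assay on HeLa cells (Homo sapiens) for antiproliferative activity, read by MTT assay, with a stated time of 72 h (a lower number here means a stronger inhibitor, a higher number a weaker inhibitor), compound 1 gives 3000 nM, the lowest of the three numbers measured, though every neighbour sits within the scatter of it. Compound 2 `COc1cc(C(=O)c2sc3ccccc3c2-c2ccc(C)cc2)cc(OC)c1OC` gives 3700 nM in this assay, and compound 3 `COc1ccc(-c2c(C(=O)c3cc(OC)c(OC)c(OC)c3)sc3ccccc23)c(OC)c1` gives 3900 nM. The steps among them are small: a 1.2-fold higher number from compound 1 to compound 2 (0.09 log units; within the scatter), a 1.3-fold higher number from compound 1 to compound 3 (0.11 log units; within the scatter) and a 1.1-fold higher number from compound 2 to compound 3 (0.02 log units; within the scatter), none of them beyond the scatter.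

Compound 4 `CCOc1ccc(Nc2c(C(=O)c3cc(OC)c(OC)c(OC)c3)sc3ccccc23)cc1` has not yet been measured in this assay. Its difference from compound 1 is (4-ethoxyphenyl)amino in place of 4-fluorophenyl on an aromatic carbon. The three measured steps all exchange the group on that same aromatic carbon of the core, and each of them left the number essentially where it was. They therefore bear on the present step only loosely, since none of them introduced an amino link or a hydrogen-bond donor, and the data say nothing about such a group. On the evidence of the small steps seen so far, the expected step of no change at the digits printed from compound 1 to compound 4 (within the scatter) is none beyond the scatter, with a wide margin of uncertainty. Compound 4 is estimated at 3000 nM in this assay, within a range from 700 nM to 13000 nM.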

Compound 4, half-maximal inhibitory concentration: 700 nM
Compound 4: middle estimate off by 4.3-fold (0.63 log units), on the high side; measured number inside the range.
By their numbers in this assay, from the lowest: compound 4; then compounds 1, 2 and 3 (each within the scatter of the next).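

At this aromatic carbon of the five-membered ring, the three phenyl groups joined directly to the core had given numbers within the scatter of one another, so the position could have seemed indifferent to what it carries. In this assay the change to (4-ethoxyphenyl)amino gives a 4.3-fold lower number from compound 1 to compound 4 (0.63 log units; beyond the scatter) and a 5.3-fold lower number from compound 2 to compound 4 (0.72 log units; beyond the scatter) and also a 5.6-fold lower number from compound 3 to compound 4 (0.75 log units; beyond the scatter) and so the position does respond, with compound 4 the only one of the four set apart beyond the scatter from all the others. Nothing measured here explains this shift, and no separate data on these compounds bear on why it occurs.

The compounds shown leave open whether the gain belongs to the amino link or to the ethoxy group, since compound 4 differs from the others in both at once, and a (4-fluorophenyl)amino group would separate the two. They also leave open how far the trend runs along the chain, for instance with a methoxy or propoxy group in place of the ethoxy, and whether a methyl group on the amino nitrogen would keep the lower number.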